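This account rests on a few compounds, and the source may have more. Where it says the series, first, only, none or still open, it means among the compounds named here.

Of the compounds shown here, three sharing one core have been read in an ADME assay for permeability, using PAMPA; on this read-out lower numbers stand for lower permeability and higher numbers for higher permeability. There, compound 1 `O=C(Nc1ccc([N+](=O)[O-])cc1)c1cc(Cl)ccc1O` gives 127 10^-6 cm/s and compound 2 `O=C(Nc1ccc(F)cc1)c1cc(Cl)ccc1O` gives 391 10^-6 cm/s. Compound 3 `NS(=O)(=O)c1ccc(NC(=O)c2cc(Cl)ccc2O)cc1` gives < 1 10^-6 cm/s, which is a limit of the assay and not a number. On these data alone, it therefore stands at the limit of < 1 10^-6 cm/s in this assay, at which 1 of the 3 values shown sits, and its exact place on the scale is unknown.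

Compound 4 `O=C(Nc1ccc(C(F)(F)F)cc1)c1cc(Cl)ccc1O` has trifluoromethyl in place of sulfamoyl on an aromatic carbon, para to a large group: trifluoromethyl in place of sulfamoyl on an aromatic carbon. Going by the values given here, three measured steps bear on this change. Two of them bring sulfamoyl onto the same carbon, and both are large: an at least 120-fold lower number from compound 1 to compound 3 (2.10 log units; beyond the scatter) and an at least 390-fold lower number from compound 2 to compound 3 (2.59 log units; beyond the scatter). The third exchanges two groups with no sulfamoyl involved and is only modest: a 3.1-fold higher number from compound 1 to compound 2 (0.49 log units; beyond the scatter). Compound 4 loses sulfamoyl, so it is expected to read in the region of compound 1 and compound 2, not near compound 3. A large step to a higher number is therefore expected in this assay. The estimated size of that rise is an at least 300-fold higher number from compound 3 to compound 4 (2.47 log units; beyond the scatter). For compound 4 the expected value is 300 10^-6 cm/s, with an estimated range of 100 10^-6 cm/s to 700 10^-6 cm/s.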

Compound 4, apparent permeability: < 22.3 10^-6 cm/s
Compound 4 gave a limit, no number; the forecaster's own chance of this, stated with the estimate: 5%; at least 13-fold (1.12 log units) between middle value and limit.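

In this assay compound 4 gives a limit of the assay and not a number: the limit of < 22.3 10^-6 cm/s in this assay, at which 1 of the 4 values shown sits. Losing sulfamoyl is therefore not enough to bring a compound up to the readings seen with the fluoro and nitro groups, as trifluoromethyl on this aromatic carbon, para to a large group, gives an at least 17-fold lower number from compound 2 to compound 4 (1.24 log units; beyond the scatter) and an at least 5.6-fold lower number from compound 1 to compound 4 (0.75 log units; beyond the scatter), so sulfamoyl is no longer the only group here tied to a low reading. Compound 3 and compound 4 both stand as limits, and the step between them cannot be read, so the two groups cannot be placed in order on this scale.

The compounds shown leave open where compound 4 really lies on the scale, and so how far trifluoromethyl stands from the other groups beyond what its limit allows. They also leave open how other groups on this same carbon would read, such as a methyl, a methoxy, a nitrile, an amine or a carboxylic acid, and so whether the readings of the four compounds follow any wider pattern.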